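Ethyl for methyl on the aromatic nitrogen, amine series

The compounds below may be only part of what the source reports. "The series", "measured", "known", "first", "only" and "open" are said of these compounds alone.

Measured so far:
compound 1 `CCn1ccc(N2C[C@H](COC)OC2=O)c1`: 1300 nM
compound 2 `CNC[C@H]1CN(c2ccn(C)c2)C(=O)O1`: > 100000 nM

In an assay for inhibition of Amine oxidase [flavin-containing] B (Bos taurus), read by fluorescence, with a stated time of 30 min (on this read-out higher numbers stand for weaker inhibition and lower numbers for stronger inhibition), compound 1 gives 1300 nM. For compound 2 this assay records only a limit, > 100000 nM, which is the limit of > 100000 nM in this assay, at which 1 of the 2 values shown sits. Compound 3 `CCn1ccc(N2C[C@H](CNC)OC2=O)c1` is compound 2 carrying (methyl in place of hydrogen on a saturated chain carbon bound to an aromatic nitrogen). Among the measured compounds shown here, no measured pair isolates this change, so the expected step of an at least 1.2-fold lower number from compound 2 to compound 3 (0.09 log units; that floor lies within the scatter) is taken as small, not beyond the scatter, in either direction. Compound 3 is therefore estimated at 80000 nM in this assay, with a range from 15000 nM to 400000 nM and a fair chance that only a limit is reported again.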

Compound 3, inhibition constant: 18000 nM
Compound 3: middle estimate off by 4.4-fold (0.65 log units), on the high side, and the stated range covers the measured number.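

In this assay, methyl in place of hydrogen on a saturated chain carbon bound to an aromatic nitrogen gives an at least 5.5-fold lower number from compound 2 to compound 3 (0.74 log units; beyond the scatter) in the amine series, so this position responds to a single added carbon. That step is a floor only, as compound 2 stands at a limit: the limit of > 100000 nM in this assay, at which 1 of the 3 values shown sits. With ethyl held constant, methylamino in place of methoxy still gives a 14-fold higher number from compound 1 to compound 3 (1.14 log units; beyond the scatter) and remains the larger printed cost.

Going by these compounds, the true size of the ethyl step stays open. So does whether a propyl chain on the aromatic nitrogen, or a primary amine in place of methylamino, would lower the number further.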